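Bromo on the oxindole ring of a naphthyl pyrazoline

A few compounds are considered here, and "the series" means these few. Any claim that something is new, unique, unknown or untested is made for them only; others in the source may bear on it.

Compound 1 `COc1ccc(C2CC(c3ccccc3)=NN2C2=NC(=O)/C(=C3\C(=O)Nc4ccc(Br)cc43)S2)cc1`: 360 nM
Compound 2 `COc1ccc(C2=NN(C3=NC(=O)/C(=C4\C(=O)Nc5ccc(Br)cc54)S3)C(c3ccc(OC)cc3)C2)cc1`: 380 nM
Compound 3 `COc1ccc(C2CC(c3ccc4ccccc4c3)=NN2C2=NC(=O)/C(=C3\C(=O)Nc4ccccc43)S2)cc1`: 13600 nM

In a functional assay on cells (Cancer cell lines, Homo sapiens) for cytotoxicity, read by sulforhodamine B assay, with a stated time of 48 h (a higher number here means a weaker inhibitor of growth, a lower number a stronger inhibitor of growth), compound 3 gives the highest number of the three, and its gaps to compound 1 and compound 2 both lie beyond the scatter. Compound 4 `COc1ccc(C2CC(c3ccc4ccccc4c3)=NN2C2=NC(=O)/C(=C3\C(=O)Nc4ccc(Br)cc43)S2)cc1` differs from compound 3 by bromo in place of hydrogen on an aromatic carbon. For the measured compounds named here, no measured step isolates this change: the only single step, a 1.1-fold higher number from compound 1 to compound 2 (0.02 log units; within the scatter), concerns a methoxy group elsewhere and says nothing about bromo. Compound 1 and compound 2 carry the bromo but also a different aryl group on the pyrazoline, so their lower numbers cannot be credited to bromo alone. Compound 4 is therefore expected at 2000 nM (range 400 nM to 12000 nM), an estimated step of a 6.8-fold lower number from compound 3 to compound 4 (0.83 log units; beyond the scatter) in this assay, with the direction uncertain.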

Compound 4, concentration for total growth inhibition: 330 nM
Beside the measured number, compound 4's estimate is 6.1-fold (0.78 log units) above it; the measured number lies below the stated range.
By their numbers in this assay, from the lowest: compounds 4, 1 and 2 (each within the scatter of the next); then compound 3.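

In this assay a single step now isolates bromo in place of hydrogen on this aromatic carbon, and it is large: a 41-fold lower number from compound 3 to compound 4 (1.62 log units; beyond the scatter). With bromo present, the aryl groups on the carbon with a double bond to nitrogen are not told apart, with a 1.2-fold lower number from compound 2 to compound 4 (0.06 log units; within the scatter) and a 1.1-fold lower number from compound 1 to compound 4 (0.04 log units; within the scatter). No evidence at hand accounts for the size of the bromo step.

The compounds shown leave open whether the bromo step holds with phenyl or 4-methoxyphenyl in place of naphthalen-2-yl. They also leave open whether chloro, an amine or a carboxylic acid on the same carbon would match bromo.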